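The compounds below may be only part of what the source reports. "The series", "measured", "known", "first", "only" and "open" are said of these compounds alone.

Compound 1 `O=C(O)CCNC(=O)c1ccc(CN(c2ccc(Cl)cc2)c2nc(-c3ccc(OC(F)(F)F)cc3)cs2)cc1` was tested in an assay on membranes from liver for binding affinity to Glucagon receptor (Rattus norvegicus) (on this read-out higher numbers stand for weaker inhibition and lower numbers for stronger inhibition), where compound 1 gives 1700 nM. Its companion, compound 2 `O=C(O)CCNC(=O)c1ccc(CN(c2ccc3c(c2)CCCC3)c2nc(-c3ccc(Cl)c(Cl)c3)cs2)cc1`, gives 1600 nM in this assay, and the two numbers lie within the scatter of each other, so no order between compound 1 and compound 2 can be read from them. The step to compound 3 `O=C(O)CCNC(=O)c1ccc(CN(c2ccc(Cl)cc2)c2nc(-c3ccc(C(F)(F)F)cc3)cs2)cc1` is a small one: trifluoromethyl in place of trifluoromethoxy on an aromatic carbon. Among the measured compounds shown here, no measured pair shows this exact change. Compound 3 is expected to stay near compound 1, with a step of a 1.1-fold lower number from compound 1 to compound 3 (0.05 log units; within the scatter) that lies within the scatter, so compound 3 is estimated at 1500 nM, between 600 nM and 4000 nM.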

Compound 3, half-maximal inhibitory concentration: 1400 nM
Compound 3: middle estimate off by 1.1-fold (0.03 log units), on the high side, within the range that was stated.
By their numbers in this assay, from the lowest: compounds 3, 2 and 1 (each within the scatter of the next).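

In this assay, among the compounds shown here, trifluoromethyl in place of trifluoromethoxy at this position, para to a large group, gives a 1.2-fold lower number from compound 1 to compound 3 (0.08 log units; within the scatter), the first step that differs in one place. The pair therefore allows no order: the two groups cannot be told apart on this read-out. No measured evidence bears on why this is so. Still open, from the compounds shown here alone, is whether an amine, a carboxylic acid or a nitrile on this same aromatic carbon would also stay within the scatter of compound 1.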